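Swapping fluoro for chloro on a hydroxymethyl benzofuran amidoxime

The source may hold more compounds than are shown below. What is called first, only, known or untested is meant among the compounds shown, and "the series" means these compounds.

Compound 1: `O/N=C(/Nc1cccc(Cl)c1)c1ccc2occc2c1` — 690 nM
Compound 2: `OCc1cc2cc(/C(=N\O)Nc3cccc(F)c3)ccc2o1` — 1700 nM

Of the compounds shown here, two have been measured in an assay on isolated protein for inhibition of Indoleamine 2,3-dioxygenase 1 (Homo sapiens), read by spectrophotometry; a higher number here means a weaker inhibitor, a lower number a stronger inhibitor. Compound 1 gives 690 nM, and compound 2 gives 1700 nM, the higher of the two numbers; the gap between them lies beyond the scatter, so compound 2 is the weaker inhibitor of the pair. The two differ in more than one place, so no single step can be read from them.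

Compound 3, `OCc1cc2cc(/C(=N\O)Nc3cccc(Cl)c3)ccc2o1`, is the not yet measured analogue. Against compound 2 it shows (chloro in place of fluoro on an aromatic carbon), meta to a large group, otherwise keeping the shared core of compound 2 unchanged. Within the data shown here, no directly comparable step is known, so the expectation rests only on the two numbers above. Compound 3 is expected to give 1000 nM in this assay, within a range of 400 nM to 2500 nM. That estimate means a modest step from compound 2 to compound 3 of a 1.7-fold lower number from compound 2 to compound 3 (0.23 log units; within the scatter), expected to land near the edge of the scatter.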

Compound 3, half-maximal inhibitory concentration: 8000 nM
For compound 3 the middle estimate is 8.0-fold (0.90 log units) below the measured one, and the stated range ends below it.
By their numbers in this assay, from the lowest: compound 1; then compound 2; then compound 3.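

In this assay the 3-fluorophenyl to 3-chlorophenyl change gives a 4.7-fold higher number from compound 2 to compound 3 (0.67 log units; beyond the scatter), so with the hydroxymethyl present this position responds to the choice of halogen, and chloro gives the weaker inhibitor of this pair. Among these compounds, with chloro held fixed, hydroxymethyl in place of hydrogen on an aromatic carbon gives a 12-fold higher number from compound 1 to compound 3 (1.06 log units; beyond the scatter), the first reading of that group alone and the larger of the two steps. Nothing among the data shown accounts for either step.

Among the compounds shown here, whether the change from fluoro to chloro would have the same size without the hydroxymethyl remains open, as the fluoro compound is seen only with that group. Also open, going by these compounds, is how a bromo or methyl group would behave at this position, or a methoxymethyl group or carboxylic acid in place of the hydroxymethyl.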